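The compounds below may be only part of what the source reports. "The series", "measured", "known", "first", "only" and "open" are said of these compounds alone.

Measured compounds:
- compound 2, `O=C(Nc1ccccc1)N1CCC(CN(Cc2ccc(Cl)cc2)Cc2ccc([N+](=O)[O-])s2)C1` — a functional assay on HEK293 cells for agonist activity at nuclear receptor subfamily 1 group D member 1 (Homo sapiens), read by a luciferase reporter, with a stated time of 24 h; a lower number here means that less compound is needed, a higher number that more compound is needed for the effect: 620 nM
- compound 1, `O=[N+]([O-])c1ccc(CN(Cc2ccc(Cl)cc2)CC2CCN(Cc3ccccc3)C2)s1` — this assay: "not determined" (no result reported)

Among the compounds with values here, compound 2 carries the only number on hand in this assay; compound 1, its close relative with a benzyl group on the ring nitrogen in place of the phenylurea, has no reported value, so nothing can be said of how that swap moves potency. Compound 2 therefore stands alone as the reference point for the series, with nothing to rank it against.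

Compound 3, `O=C(Nc1ccc([N+](=O)[O-])cc1)N1CCC(CN(Cc2ccc(Cl)cc2)Cc2ccc([N+](=O)[O-])s2)C1`, is the untested member. It differs from compound 2 by nitro in place of hydrogen on an aromatic carbon. Within the data shown here, no measured pair in this set shows what such a change does in this assay, so the direction of the step is open. Among the measured compounds shown here, with a single reference and no precedent, the step is expected to be modest, of a size not clearly beyond the ordinary scatter, with a slight lean toward a smaller number, and the estimate for compound 3 is written as a 1.4-fold lower number from compound 2 to compound 3 (0.14 log units; within the scatter). On that basis compound 3 is expected to give about 450 nM in this assay, with a plausible range from 120 nM to 1800 nM.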

Compound 3, half-maximal effective concentration: 400 nM
Compound 3: middle estimate off by 1.1-fold (0.05 log units), on the high side; low and high end bracket the measured number.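

In this assay, nitro in place of hydrogen on an aromatic carbon, para to a large group, gives a 1.6-fold lower number from compound 2 to compound 3 (0.19 log units; within the scatter), so compound 2 and compound 3 cannot be told apart in this read-out. Within the data shown here, this is the first sign for this position: the change from phenylcarbamoyl to (4-nitrophenyl)carbamoyl adds three heavy atoms on the six-membered aromatic ring without a step beyond the scatter, though this single pair says nothing about any other group at this place. No measurement on hand bears on the origin of this step.

Still open, as far as these compounds go, is whether any group at this place can move the number beyond the scatter, and an amine, a carboxylic acid, a methoxy group or a longer chain on the same aromatic carbon would test that. Also open, from the compounds shown here alone, is whether nitro would behave the same way at other places on this ring or on a core carrying a group other than phenylcarbamoyl on the ring nitrogen.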